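The source may report more compounds than this note shows. Statements on the series, on what has been measured and on what is new or still open speak of the compounds shown alone.

Measured compounds:
- compound 1, `Cc1cccc(-c2nnc(-c3sc(-c4cccnc4)nc3C)o2)c1`, an ADME assay on HeLa cells (Homo sapiens) for cytotoxicity, read by MTT assay; a higher number here means that more compound is tolerated, a lower number that less compound is tolerated: > 100 ug/mL (a limit)
- compound 2, `Cc1ccc(-c2nnc(-c3sc(-c4cccnc4)nc3C)o2)cc1`, this assay: > 100 ug/mL (a limit)

Compound 2 sits at the upper limit of this assay, where the reading of > 100 ug/mL is a limit and not a number. The same is true of compound 1, for which the reading of > 100 ug/mL is also a limit. The step that the two limits leave unreadable from compound 1 to compound 2 is therefore not readable in size, as the limit of > 100 ug/mL in this assay, at which 2 of the 2 values shown sit, shows.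

Compound 3, `Cc1nc(-c2cccnc2)sc1-c1nnc(-c2cccnc2)o1`, differs from compound 2 in one place: pyridin-3-yl in place of 4-methylphenyl on an aromatic carbon. Among the measured compounds shown here, no measured step bears directly on this change, since the only measured pair stays at the limit on both sides. The expectation for compound 3 is therefore that it too is tolerated up to the limit, with the step that the limit leaves unreadable from compound 2 to compound 3 expected to stay within the scatter. Compound 3 is estimated at 150 ug/mL, with a range from 70 ug/mL to 300 ug/mL.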

Compound 3, half-maximal cytotoxic concentration: > 100 ug/mL
Compound 3: a limit, no number (the forecaster's own chance of this, stated with the estimate: 80%); the middle value lies beyond the limit too.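

In this assay, compound 3 also gives only a limit, so no step among compound 1, compound 2 and compound 3 can be read in size: the limit of > 100 ug/mL in this assay, at which 3 of the 3 values shown sit.

The compounds shown leave open how much of each is actually tolerated, and whether 3-methylphenyl, 4-methylphenyl and pyridin-3-yl differ at all.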